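From 4-methylphenyl to 2-fluorophenyl on the carbonyl carbon

The compounds below may be only part of what the source reports. "The series", "measured", "known", "first", "only" and "open" are said of these compounds alone.

Of the compounds shown here, two have been measured in a functional assay on OVCAR-3 cells (Homo sapiens) for antiproliferative activity, read by MTT assay, with a stated time of 24 h; on this read-out lower numbers stand for stronger inhibition and higher numbers for weaker inhibition. For the measured compounds named here, compound 1 (`O=C(NNc1ccccc1F)c1ccccc1NS(=O)(=O)c1cnc(O)nc1O`) gives 9570 nM and compound 2 (`Cc1ccc(C(=O)NNC(=O)c2ccccc2NS(=O)(=O)c2cnc(O)nc2O)cc1`) gives 12900 nM, so compound 2 stands within the scatter of the only other measured value. Compound 3 (`O=C(NNC(=O)c1ccccc1NS(=O)(=O)c1cnc(O)nc1O)c1ccccc1F`) has 2-fluorophenyl in place of 4-methylphenyl on a carbonyl carbon. Going by the values given here, the one measured step that bears on this is a 1.3-fold higher number from compound 1 to compound 2 (0.13 log units; within the scatter), which puts (4-methylphenyl)carbonyl in place of 2-fluorophenyl on an amine nitrogen and lies within the scatter. Among the compounds with values here, it is not the same exchange, and the data hold no direct precedent for it, but it gives no sign of a large move. The expected 1.2-fold lower number from compound 2 to compound 3 (0.07 log units; within the scatter) therefore stays within the scatter, with no direction favoured. The estimate for compound 3 is 11000 nM, with an expected range from 5000 nM to 25000 nM.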

Compound 3, half-maximal inhibitory concentration: 15300 nM
The estimate for compound 3 lay 1.4-fold (0.14 log units) below the measured number; the measured number falls inside the stated range.
By their numbers in this assay, from the lowest: compounds 1, 2 and 3 (each within the scatter of the next).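

In this assay the direct exchange on the carbonyl carbon gives a 1.2-fold higher number from compound 2 to compound 3 (0.07 log units; within the scatter), so 2-fluorophenyl and 4-methylphenyl cannot be told apart at this position. Adding the carbonyl to the 2-fluorophenyl group on the amine nitrogen gives a 1.6-fold higher number from compound 1 to compound 3 (0.20 log units; within the scatter) and likewise stays within the scatter, so the three compounds cannot be ranked. No available evidence offers an explanation for these readings.

Every compound shown ends in a six-membered aromatic ring of carbon only, so what an amine, a carboxylic acid or a longer chain would do in that place stays open. For the compounds shown here, also open is whether the read-out responds at all to changes at this end of the shared core, since no step here lies beyond the scatter.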